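Swapping a thiazole for a pyridine on a sulfonamide

The source may report more compounds than this note shows. Statements on the series, on what has been measured and on what is new or still open speak of the compounds shown alone.

Measured compounds:
compound 1, `Cc1nc2c(c(-c3ccccc3)cn2-c2ccc(S(=O)(=O)Nc3nccs3)cc2)c(=O)[nH]1`, gives 5800 nM
compound 2, `Cc1nc2c(c(-c3ccccc3)cn2-c2ccc(S(=O)(=O)Nc3ccccn3)cc2)c(=O)[nH]1`, gives 5100 nM
compound 3, `Nc1nc(=O)[nH]c2c1c(-c1ccccc1)cn2-c1ccc(S(=O)(=O)Nc2nccs2)cc1`, gives 8320 nM

All three were tested in a functional assay on MCF7 cells (Homo sapiens) for inhibition, read by sulforhodamine B assay, with a stated time of 24 h; a higher number here means a weaker inhibitor, a lower number a stronger inhibitor. The three values lie close together, and none of them stands apart from the others by more than the usual scatter of such measurements.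

Compound 1 and compound 2 share one core and differ in a single place, namely (pyridin-2-yl in place of 1,3-thiazol-2-yl on a sulfonamide nitrogen). The step that this change made was a 1.1-fold lower number from compound 1 to compound 2 (0.06 log units; within the scatter), so within this pair the swap left the result essentially unchanged.

Compound 3 carries a different core; how the two cores differ is not broken down here. Compound 4, `Nc1nc(=O)[nH]c2c1c(-c1ccccc1)cn2-c1ccc(S(=O)(=O)Nc2ccccn2)cc1`, has not yet been measured. It is related to compound 3 by the same change as compound 2 is to compound 1: pyridin-2-yl in place of 1,3-thiazol-2-yl on a sulfonamide nitrogen. The surroundings of the changed group are the same in both pairs, a sulfonamide nitrogen bonded to a sulfonyl sulfur.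

Among the measured compounds shown here, because the only known instance of this change, a 1.1-fold lower number from compound 1 to compound 2 (0.06 log units; within the scatter), stayed within the scatter, the step from compound 3 to compound 4 is expected to be similarly small, estimated as a 1.1-fold lower number from compound 3 to compound 4 (0.05 log units; within the scatter). Starting from compound 3 at 8320 nM, compound 4 is therefore estimated to give about 7500 nM in this assay, with a plausible range from 3500 nM to 16000 nM. This rests on a single matched pair, so the expectation is loosely held.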

Compound 4, half-maximal inhibitory concentration: 3900 nM
Estimate against measurement, compound 4: 1.9-fold (0.28 log units) above, and the stated range covers the measured number.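

In this assay, the swap to pyridin-2-yl in place of 1,3-thiazol-2-yl on a sulfonamide nitrogen now gives a 2.1-fold lower number from compound 3 to compound 4 (0.33 log units; beyond the scatter), a modest step that stands out from the usual noise of the measurement. Set beside the earlier step on the other core, the new step cannot be told apart from it: the same change on two cores in this assay, a 1.1-fold lower number (0.06 log units; within the scatter) from compound 1 to compound 2 and a 2.1-fold lower number (0.33 log units; beyond the scatter) from compound 3 to compound 4, 1.9-fold (0.27 log units) apart, within the scatter of two such steps. Among the compounds shown here, this shows that, as far as these numbers can tell, the swap behaves alike on both cores, even though only the step on the core of compound 3 is large enough to read as a real change; it does not show that the core alters the size of the step, nor that the step would hold on a third core, and two pairs are a thin base for any general rule.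

The compounds shown leave open whether other groups on the sulfonamide nitrogen, such as a pyrimidin-2-yl ring or a simple methyl group, would do as well as pyridin-2-yl or better. They also leave open whether the same swap would give a similar step in a cell line other than this one.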